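Ethoxy to Methoxy in a Chemokine Receptor Antagonist Series

The compounds below may be only part of what the source reports. "The series", "measured", "known", "first", "only" and "open" are said of these compounds alone.

Three compounds have been measured in an assay on blood for inhibition of C-X-C chemokine receptor type 3 (Homo sapiens), with a stated time of 30 min; on this read-out higher numbers stand for weaker inhibition and lower numbers for stronger inhibition:

Compound 1, `C[C@@H]1CN(c2scnc2-c2nc3ccccc3[nH]2)CCN1C(=O)Cn1cnc2cccnc21`, gives 554 nM.
Compound 2, `CC[C@@H]1CN(c2scnc2-c2nc3ccccc3[nH]2)CCN1C(=O)Cn1cnc2cccnc21`, gives 851 nM.
Compound 3, `CCOc1ncc(-c2nc(C(F)(F)F)sc2N2CCN(C(=O)Cn3nc(C)nc3C)[C@H](C)C2)cn1`, gives 364 nM.

Compounds 1 and 2 share one core and differ by hydrogen in place of methyl on a saturated chain carbon bound to a saturated ring carbon; this step brought a 1.5-fold lower number from compound 2 to compound 1 (0.19 log units; within the scatter) in this assay. Compound 3 rests on another core, and the difference between the two cores is not broken down here. Its value in this assay sits within the scatter of that of compound 1 and beyond the scatter of that of compound 2.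

Compound 4, `COc1ncc(-c2nc(C(F)(F)F)sc2N2CCN(C(=O)Cn3nc(C)nc3C)[C@H](C)C2)cn1`, has not yet been measured. It differs from compound 3 by hydrogen in place of methyl on a saturated chain carbon bound to an oxygen on an aromatic ring. This is the same kind of change as that from compound 2 to compound 1, since in both a methyl leaves and a hydrogen enters, but the surroundings differ: there the change sat on a saturated chain carbon bound to a saturated ring carbon, here it sits on a saturated chain carbon bound to an oxygen on an aromatic ring. That earlier step stayed within the scatter, and on that single precedent the step from compound 3 to compound 4 is also expected to be small, a 1.1-fold higher number from compound 3 to compound 4 (0.04 log units; within the scatter). Among the measured compounds shown here, compound 4 is therefore estimated at 400 nM in this assay, with a range from 150 nM to 1100 nM reflecting that only one comparable step, at a different place, is available.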

Compound 4, half-maximal inhibitory concentration: 1040 nM
Beside the measured number, compound 4's estimate is 2.6-fold (0.41 log units) below it, within the range that was stated.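

In this assay, shortening ethoxy to methoxy on the 2-ethoxypyrimidin-5-yl group gave a 2.9-fold higher number from compound 3 to compound 4 (0.46 log units; beyond the scatter), so here the loss of a methyl in favour of a hydrogen moved the number clearly upward. Set beside the earlier case, the same formal change did not carry over unchanged from one core to the other: the same change on two cores in this assay, a 1.5-fold lower number (0.19 log units; within the scatter) from compound 2 to compound 1 and a 2.9-fold higher number (0.46 log units; beyond the scatter) from compound 3 to compound 4, 4.4-fold (0.64 log units) apart, beyond the scatter of two such steps. This shows that, among these compounds, the size of this change cannot be taken from one core to the next, but it does not show whether the core or the place of the change sets the difference, since the two pairs differ in both, and two pairs establish no rule for the series.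

The compounds shown leave open whether a longer chain such as propoxy, or an amine in the place of the ethoxy, would lower the number further or raise it again. They also leave open whether the step from compound 2 to compound 1, repeated at the same place on the core of compound 3, would stay within the scatter, which would help to separate the effect of the core from that of the place.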